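The compounds below may be only part of what the source reports. "The series", "measured", "known", "first", "only" and "open" are said of these compounds alone.

Working notes on the series. The shared core carries a methoxy-substituted bicyclic amine linked through a saturated chain to a urea. Compound 1 `COc1cc(NC(C)CCCNC(=O)NC(c2ccccc2)c2ccccc2)c2ncccc2c1` bears a diphenylmethyl group on the urea nitrogen. In an ADME assay on WI-38 cells (Homo sapiens), read by MTT assay, with a stated time of 72 h (a lower number here means a stronger inhibitor, a higher number a weaker inhibitor), compound 1 gives only a limit, > 100000 nM. Going by the values given here, compound 2 `COc1cc(NC(C)CCCNC(=O)NCc2ccncc2)c2ncccc2c1` carries a (pyridin-4-yl)methyl group instead; in this assay compound 2 gives 10000 nM, the one numeric value shown. Compound 3 `COc1cc(NC(C)CCCNC(=O)NCc2ccccc2)c2ncccc2c1` is yet to be measured. It differs from compound 2 by phenyl in place of pyridin-4-yl on a saturated chain carbon bound to an amide-type nitrogen. Among the compounds with values here, no measured pair isolates this change, so the step from compound 2 to compound 3 is expected to stay within the scatter, a 1.5-fold higher number from compound 2 to compound 3 (0.18 log units; within the scatter). Compound 3 is estimated at 15000 nM, within 4000 nM to 60000 nM.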

Compound 3, half-maximal inhibitory concentration: 35000 nM
Estimate against measurement, compound 3: 2.3-fold (0.37 log units) below, and the stated range covers the measured number.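

In this assay phenyl in place of pyridin-4-yl on a saturated chain carbon bound to an amide-type nitrogen gives a 3.5-fold higher number from compound 2 to compound 3 (0.54 log units; beyond the scatter) and so shows that this position responds to the ring change beyond the scatter. Hydrogen in place of phenyl on a saturated chain carbon bound to an amide-type nitrogen and an aromatic carbon gives an at least 2.8-fold lower number from compound 1 to compound 3 (0.45 log units; beyond the scatter) as a second step at this place. That step is only a bound, because compound 1 stands at a limit of the assay: the limit of > 100000 nM in this assay, at which 1 of the 3 values shown sits.

Open, on these data alone, is how a pyridin-3-yl group or a longer chain in place of benzyl would read in this assay for this series.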